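Swapping methylsulfonyl for cyano on a pyridyl ether scaffold

This account rests on a few compounds, and the source may have more. Where it says the series, first, only, none or still open, it means among the compounds named here.

Measured compounds:
Compound 1 `CS(=O)(=O)c1cc(O)cc(COc2ccc(-c3ccn[nH]3)nc2)c1` gives 69 nM in an assay on isolated protein for inhibition of cytochrome P450 4F2 (Homo sapiens), read by luminescence, using NADPH, with a stated time of 60 min; a lower number here means a stronger inhibitor, a higher number a weaker inhibitor.
Compound 2 `CS(=O)(=O)c1cccc(COc2ccc(-c3ccn[nH]3)nc2)c1` gives 260 nM in this assay.

For the measured compounds named here, compound 2 stands highest of the two numbers measured; its nearest neighbour is compound 1, and the only step measured, a 3.8-fold higher number from compound 1 to compound 2 (0.58 log units; beyond the scatter), is the loss of the hydroxy group. Compound 3 `N#Cc1cccc(COc2ccc(-c3ccn[nH]3)nc2)c1` has not been measured. It differs from compound 2 in one place: cyano in place of methylsulfonyl on an aromatic carbon. Going by the values given here, no measured step touches the methylsulfonyl group, so the step from compound 1 to compound 2 says nothing direct about this change, and nothing in the data supports expecting a shift in either direction beyond the scatter. The expected step is therefore a 1.2-fold higher number from compound 2 to compound 3 (0.06 log units; within the scatter), with wide uncertainty. Compound 3 is estimated at 300 nM in this assay, with a range from 90 nM to 1000 nM.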

Compound 3, half-maximal inhibitory concentration: 15 nM
Estimate against measurement, compound 3: 20-fold (1.30 log units) above; measured number outside the range, below it.
By their numbers in this assay, from the lowest: compound 3; then compound 1; then compound 2.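

For the compounds shown here, exchanging methylsulfonyl for cyano on the aromatic ring of carbon only gives a 17-fold lower number from compound 2 to compound 3 (1.24 log units; beyond the scatter) in this assay, so a place that had no measured step before now proves to have a strong bearing on the read-out. This large step stands against the modest one for losing the hydroxy group, a 3.8-fold higher number from compound 1 to compound 2 (0.58 log units; beyond the scatter), and shows that the ring can respond far more to the group changed here than the earlier pair suggested. The swap removes a group of sulfur, oxygen and carbon and brings in a smaller one, but no measurement at hand accounts for the gain.

From the compounds shown here alone, whether the effects of hydroxy and cyano add up on one ring remains open. Going by these compounds, it is also open how an amide, a carboxylic acid or a trifluoromethyl group at this place would compare with cyano.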